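Methyl in place of hydrogen on a weakly active compound

The source may hold more compounds than are shown below. What is called first, only, known or untested is meant among the compounds shown, and "the series" means these compounds.

In a functional assay on MIA PaCa-2 cells (Homo sapiens) for antiproliferative activity, read by sulforhodamine B assay, with a stated time of 48 h (on this read-out lower numbers stand for stronger inhibition and higher numbers for weaker inhibition), compound 1 `COc1cc(C(=O)/C=C\Nc2ccc(-c3nc4cc(OC)c(OC)c(OC)c4s3)cc2)c(Br)c(OC)c1OC` gives 23200 nM. Compound 3 `COc1cc(OC)c2sc(-c3ccc(N/C=C\C(=O)c4ccc(OC)c(F)c4)c(C)c3)nc2c1` gives 16300 nM, within the scatter of compound 1. Compound 2 `COc1cc(OC)c2sc(-c3ccc(N/C=C\C(=O)c4cc(OC)c(OC)c([N+](=O)[O-])c4)c(C)c3)nc2c1` gives 10400 nM, and this gap alone goes beyond the scatter, leaving compound 1 the weaker of that pair. Compound 4 `COc1cc(C(=O)/C=C\Nc2ccc(-c3nc4cc(OC)c(OC)c(OC)c4s3)cc2C)c(Br)c(OC)c1OC` has methyl in place of hydrogen on an aromatic carbon of compound 1 (methyl in place of hydrogen on an aromatic carbon). Among the compounds with values here, no measured pair isolates this change. Compound 2 and compound 3 also carry a methyl but differ elsewhere, so they only bound the expectation. No step beyond the scatter is expected in this assay. The estimated step is a 1.5-fold lower number from compound 1 to compound 4 (0.19 log units; within the scatter). For compound 4 the estimate is 15000 nM, with an expected range of 6000 nM to 35000 nM.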

Compound 4, half-maximal inhibitory concentration: 24300 nM
The estimate for compound 4 lay 1.6-fold (0.21 log units) below the measured number; the measured number falls inside the stated range.
By their numbers in this assay, from the lowest: compounds 2, 3, 1 and 4 (each within the scatter of the next, the first and the last beyond it).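

In this assay, methyl in place of hydrogen on an aromatic carbon, ortho to a large group and meta to a large group, gives a 1.0-fold higher number from compound 1 to compound 4 (0.02 log units; within the scatter). Within the data shown here, this is the first step that isolates this carbon, and it shows that the added methyl leaves the weak activity of compound 1 unchanged within the scatter. No measured evidence bears on why this step is so small. Still open, from the compounds shown here alone, is whether an amine, a hydroxyl or a longer chain such as propyl on this carbon would move the number beyond the scatter.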